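A few compounds are considered here, and "the series" means these few. Any claim that something is new, unique, unknown or untested is made for them only; others in the source may bear on it.

Of the compounds shown here, two of this set have been measured in a functional assay on the whole organism for inhibition, with Brassica rapa subsp. chinensis as the target, with a stated time of 3 days, tested at 100 ppm; on this read-out higher numbers stand for more inhibition of growth at the one concentration tested and lower numbers for less inhibition of growth. Compound 1 `C=CCNC(=O)/C=C/c1ccccc1` carries an allylamino group on the carbonyl carbon of the shared core, and in this assay compound 1 gives 63%. Compound 2 `CCC(C)OC(=O)/C=C/c1ccccc1` carries sec-butoxy in its place, and in this assay compound 2 gives 18%. Among the compounds with values here, the only measured step, a number 45 percentage points lower from compound 1 to compound 2 (beyond the scatter), is large and beyond the scatter. On the numbers shown, compound 2 therefore stands lowest of the two, its nearest neighbour being compound 1.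

Compound 3 `CCCCOC(=O)/C=C/c1ccccc1` is built from compound 2 by rearranging the same atoms: butyl in place of sec-butyl on an oxygen next to a carbonyl group. Within the data shown here, no measured step bears directly on this change: the one step that has been measured exchanges an amide for an ester and says nothing about the branching of the chain on the ester oxygen. Compound 3 is therefore expected to sit close to compound 2, with the step of a number 2 percentage points higher from compound 2 to compound 3 (within the scatter) expected to stay within the scatter. Compound 3 is estimated at 20%, with a range from 5% to 40%.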

Compound 3, percent growth inhibition at one concentration: 5%
Estimate against measurement, compound 3: 15 percentage points above; low and high end bracket the measured number.
By their numbers in this assay, from the lowest: compound 3; then compound 2; then compound 1.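

On an oxygen next to a carbonyl group, the ester chain is not indifferent to how the same four carbons are joined: in this assay, butyl in place of sec-butyl gives a number 13 percentage points lower from compound 2 to compound 3 (beyond the scatter), a modest step, and the branched ester keeps the higher number of the two. The large cost of leaving the amide also holds for the unbranched chain, which shows a number 58 percentage points lower from compound 1 to compound 3 (beyond the scatter), so that cost is not peculiar to sec-butoxy. Nothing measured alongside these growth numbers explains why the two chains differ.

As far as these compounds go, it remains open whether further branching, as in a tert-butyl ester, would raise the number again, or whether a longer chain such as hexyl would lower it further. From the compounds shown here alone, it is equally open whether the same change of chain would matter on the amide side, where a butylamino or sec-butylamino group on the carbonyl carbon would allow a comparison with allylamino, and how a free carboxylic acid would compare with these esters.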